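A few compounds are considered here, and "the series" means these few. Any claim that something is new, unique, unknown or untested is made for them only; others in the source may bear on it.

Three compounds from one series share a core, seen in compound 1 `O=C(N/N=C\c1ccccn1)c1ccc(-c2nc3ccccc3s2)cc1`, and are compared in an assay on isolated protein for inhibition of Maltase-glucoamylase (Homo sapiens), with a stated time of 15 min; a lower number here means a stronger inhibitor, a higher number a weaker inhibitor. Compound 1 gives 10200 nM. Compound 2 `COC(=O)c1ccc(/C=N/NC(=O)c2ccc(-c3nc4ccccc4s3)cc2)cc1` carries a methoxycarbonyl on its outer ring, and in this assay compound 2 is reported as "not active" (no number reported), so no single number is available for it; it therefore stands without a number against compound 1. Compound 3 `O=C(N/N=C/c1ccc(Cl)cc1)c1ccc(-c2nc3ccccc3s2)cc1` has not been measured. Compound 3 differs from compound 2 by chloro in place of methoxycarbonyl on an aromatic carbon. For the measured compounds named here, no measured step of that kind exists in this set, so the direction and size of the change in this assay cannot be read from the data. Compound 3 is expected to land near 15000 nM, within a range from 4000 nM to 60000 nM, with a real chance that this assay again reports no number.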

Compound 3, half-maximal inhibitory concentration: 5310 nM
Compound 3: the middle estimate sits 2.8-fold (0.45 log units) above what was measured, and the stated range covers the measured number.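

In this assay compound 3 returns a number where compound 2 was reported as not active, so a measurable value appears with 4-chlorophenyl in place of 4-(methoxycarbonyl)phenyl, although the size of that step cannot be read. Changing the outer group of compound 1 to 4-chlorophenyl gives a 1.9-fold lower number from compound 1 to compound 3 (0.28 log units; within the scatter), so this assay does not separate these two outer groups. Nothing available here explains either observation.

The compounds shown leave open whether the chloro itself matters or whether a measurable value would also appear with another group at the same place on the ring, such as fluoro, methyl, an amine or a carboxylic acid. They also leave open how a ring bearing no such group would compare.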